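Removing Both Methoxy Groups from the Amide Aryl Ring

The source may report more compounds than this note shows. Statements on the series, on what has been measured and on what is new or still open speak of the compounds shown alone.

Compound 2 `COc1ccc(OC)c(NC(=O)c2cccc(/C=C3\CC(=O)N(c4ccccc4)C3=O)c2)c1` carries a 2,5-dimethoxyphenyl on its amide-type nitrogen. In an ADME assay on NCM460 cells (Homo sapiens) for cytotoxicity, read by MTT assay, with a stated time of 72 h (on this read-out lower numbers stand for stronger inhibition and higher numbers for weaker inhibition), compound 2 gives > 100000 nM, which is a limit of the assay rather than a number. Its nearest measured relative, compound 1 `Cc1ccc(NC(=O)c2cccc(/C=C3\CC(=O)N(c4ccccc4)C3=O)c2)cc1C`, differs only in bearing a 3,4-dimethylphenyl at the same place. In this assay compound 1 gives > 100000 nM, again a limit. For the measured compounds named here, the step that the two limits leave unreadable from compound 1 to compound 2 therefore cannot be read, and the only evidence available is the limit of > 100000 nM in this assay, at which 2 of the 2 values shown sit, so compound 2 stands at the top of what the assay can report, with no measured step showing any direction.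

Compound 3 `O=C(Nc1ccccc1)c1cccc(/C=C2\CC(=O)N(c3ccccc3)C2=O)c1` is the next member: phenyl in place of 2,5-dimethoxyphenyl on an amide-type nitrogen. Going by the values given here, no measured step involves the change from 2,5-dimethoxyphenyl to phenyl on an amide-type nitrogen, and the one step is unreadable. Both measured compounds sit at the limit, so compound 3 is expected to sit there as well, an expected step that the limit leaves unreadable from compound 2 to compound 3. The estimate for compound 3 in this assay is 150000 nM, with a range from 50000 nM to 500000 nM.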

Compound 3, half-maximal inhibitory concentration: > 100000 nM
Compound 3: no number, only a limit; the forecaster's own chance of this, stated with the estimate: 80%; the middle value is on the limit's open side.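

In this assay compound 3 gives > 100000 nM and this is a limit, not a number. For the compounds shown here, no step among compound 1, compound 2 and compound 3 can be read, and the only evidence is: the limit of > 100000 nM in this assay, at which 3 of the 3 values shown sit. The compounds shown leave open how far any of them lies from that limit, and whether changing the group on the amide-type nitrogen alters the read-out at all.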